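From Compound 3 to Compound 4: A Chlorine Takes Over

The compounds below may be only part of what the source reports. "The series", "measured", "known", "first", "only" and "open" are said of these compounds alone.

Three analogues sharing one core were measured in an assay on CHO cells for displacement of a labelled ligand from adenosine receptor A3 (Homo sapiens), read by scintillation counting, with a stated time of 3 h; on this read-out higher numbers stand for weaker inhibition and lower numbers for stronger inhibition. Compound 1 `Cn1c(-c2ccc(F)cc2)nc2c(NC3CCCC3)ncnc21` gives 1140 nM, compound 2 `COc1ccc(-c2nc3c(NC4CCCC4)ncnc3n2C)cc1` gives 1850 nM, and compound 3 `Cc1ccc(-c2nc3c(NC4CCCC4)ncnc3n2C)cc1` gives 480 nM. Compound 3 shows the lowest number of the three: a 2.4-fold lower number from compound 1 to compound 3 (0.38 log units; beyond the scatter) and a 3.9-fold lower number from compound 2 to compound 3 (0.59 log units; beyond the scatter), whereas a 1.6-fold higher number from compound 1 to compound 2 (0.21 log units; within the scatter). Compound 4 `Cn1c(-c2ccccc2Cl)nc2c(NC3CCCC3)ncnc21` alters the 4-methylphenyl group: 2-chlorophenyl in place of 4-methylphenyl on an aromatic carbon. The measured steps only swap one small group for another on the phenyl ring, and none introduces chlorine or moves the substituent, so they bear on this change only loosely; their modest size suggests a modest step. Compound 4 is therefore expected to give a somewhat higher number, a 2.3-fold higher number from compound 3 to compound 4 (0.36 log units; beyond the scatter), with an estimate of 1100 nM ranging from 300 nM to 4000 nM.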

Compound 4, inhibition constant: 720 nM
The estimate for compound 4 lay 1.5-fold (0.18 log units) above the measured number; measured number inside the range.
By their numbers in this assay, from the lowest: compounds 3, 4, 1 and 2 (each within the scatter of the next, the first and the last beyond it).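

The 2-chlorophenyl group stays level with the 4-methylphenyl group, a 1.5-fold higher number from compound 3 to compound 4 (0.18 log units; within the scatter), and with the 4-fluorophenyl group, a 1.6-fold lower number from compound 1 to compound 4 (0.20 log units; within the scatter), while it gives a clearly lower number than the 4-methoxyphenyl group, a 2.6-fold lower number from compound 2 to compound 4 (0.41 log units; beyond the scatter). This position on the shared core therefore accepts a phenyl ring carrying chlorine about as well as one carrying methyl or fluoro. No measurement here explains this result. Which share of the step belongs to the chlorine and which to its place on the phenyl ring stays open, as does how a phenyl ring carrying an amine or a carboxylic acid would behave.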